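The compounds below may be only part of what the source reports. "The series", "measured", "known", "first", "only" and "open" are said of these compounds alone.

Compound 1 `CCCCCCCCc1ccc2c(c1)CC[C@H](C(N)(CO)CO)C2`: 3.8 mg/kg
Compound 2 `CCCCCCCCc1ccc2c(c1)CC[C@@H](C(N)(CO)CO)C2`: 0.2 mg/kg

In a functional assay on the whole organism for activation, with Mus musculus as the target (a higher number here means that more compound is needed for the effect, a lower number that less compound is needed), compound 2 at 0.2 mg/kg has the lower of the two numbers. Compound 3 `CCCCCCCCc1ccc2c(c1)CC[C@@H]([C@@](C)(N)CO)C2` carries 1-amino-1-(hydroxymethyl)ethyl in place of 1-amino-2-hydroxy-1-(hydroxymethyl)ethyl on a saturated ring carbon. Among the measured compounds shown here, the only measured step, a 19-fold lower number from compound 1 to compound 2 (1.28 log units; beyond the scatter), is large, but the fact that compounds 1 and 2 differ only in the configuration as drawn shows that it concerns configuration alone. It therefore sets no size for this exchange, although the entering group adds 1 defined stereocentre. No step beyond the scatter is expected in this assay, in either direction, and the uncertainty is wide. The expected step is no change at the digits printed from compound 2 to compound 3 (within the scatter). Compound 3 is estimated at 0.2 mg/kg, with an expected range of 0.05 mg/kg to 1 mg/kg.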

Compound 3, dose for half-maximal effect: 0.8 mg/kg
The estimate for compound 3 lay 4.0-fold (0.60 log units) below the measured number; low and high end bracket the measured number.
By their numbers in this assay, from the lowest: compound 2; then compound 3; then compound 1.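

In this assay, the exchange of 1-amino-2-hydroxy-1-(hydroxymethyl)ethyl for 1-amino-1-(hydroxymethyl)ethyl on a saturated ring carbon gives a 4.0-fold higher number from compound 2 to compound 3 (0.60 log units; beyond the scatter) and thus a step beyond the scatter. This position therefore responds to the substituent as well as to configuration, although the step is modest beside a 19-fold lower number from compound 1 to compound 2 (1.28 log units; beyond the scatter) in this series. No available evidence bears on the reason for the exchange step. Still open, as far as these compounds go, is how the opposite configuration at the new stereocentre would read, and how a phosphate ester on the remaining hydroxyl would stand.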